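A few compounds are considered here, and "the series" means these few. Any claim that something is new, unique, unknown or untested is made for them only; others in the source may bear on it.

Compound 2 `COc1ccc(C(=O)Nc2cc(Cl)cc3c(=O)cc(C(=O)O)oc23)cc1` is measured in an assay on CHO cells for agonist activity at G protein-coupled receptor GPR35 (Rattus norvegicus), read by a beta-galactosidase reporter and beta-arrestin recruitment, with a stated time of 90 min (on this read-out lower numbers stand for an effect already at smaller amounts and higher numbers for an effect only at larger amounts of compound), at 1830 nM. Two relatives give numbers within the usual scatter of it: compound 1 `Cc1cccc(C(=O)Nc2cccc3c(=O)cc(C(=O)O)oc23)c1` gives 2750 nM in this assay, and compound 3 `O=C(Nc1cc(Cl)cc2c(=O)cc(C(=O)O)oc12)c1ccc([N+](=O)[O-])cc1` gives 3140 nM. Going by the values given here, the step of a 1.7-fold higher number from compound 2 to compound 3 (0.23 log units; within the scatter) is the only one-place change measured, and it concerns a different position. Compound 4 `COc1ccc(C(=O)Nc2cccc3c(=O)cc(C(=O)O)oc23)cc1` differs from compound 2 by hydrogen in place of chloro on an aromatic carbon. Among the compounds with values here, no measured step removes the chloro, so the data give no direction for this change, and compound 1, which also lacks it, sits within the scatter of compound 2. Compound 4 is therefore expected to show a step of a 1.1-fold higher number from compound 2 to compound 4 (0.04 log units; within the scatter), and its estimated value in this assay is 2000 nM, ranging from 900 nM to 4500 nM.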

Compound 4, half-maximal effective concentration: 2160 nM
For compound 4 the middle estimate is 1.1-fold (0.03 log units) below the measured one; the range from low to high includes it.
By their numbers in this assay, from the lowest: compounds 2, 4, 1 and 3 (each within the scatter of the next).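

In this assay hydrogen in place of chloro on the aromatic carbon gives a 1.2-fold higher number from compound 2 to compound 4 (0.07 log units; within the scatter) and so, with the 4-methoxyphenyl group kept, this position shows no clear preference between the two. With hydrogen kept there, 4-methoxyphenyl in place of 3-methylphenyl on the carbonyl carbon gives a 1.3-fold lower number from compound 1 to compound 4 (0.10 log units; within the scatter) and this change also stays within the usual scatter. No measurement shown here helps explain these results. Going by these compounds, whether bromo or an amine at this position would move the number remains open. So does whether chloro matters alongside the 4-nitrophenyl group of compound 3.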